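The source may hold more compounds than are shown below. What is called first, only, known or untested is meant among the compounds shown, and "the series" means these compounds.

Compound 3 `CC1(C)Cc2c(sc(NC(=O)c3cn[nH]c3)c2C(N)=O)C(C)(C)O1` stands with the lowest number of the three measured compounds in an assay on cells for positive allosteric modulation of Cystic fibrosis transmembrane conductance regulator variant F508del (Homo sapiens), with stated times of 10 min and 7 s, in the presence of a further agent that is not named here (a lower number here means that less compound is needed, a higher number that more compound is needed for the effect), where compound 3 gives 125 nM. Compound 1 `CC1(C)Cc2c(sc(NC(=O)c3cccnc3O)c2C(N)=O)C(C)(C)O1` gives 190 nM in this assay, and compound 2 `CC1(C)Cc2c(sc(NC(=O)c3nnc[nH]3)c2C(N)=O)C(C)(C)O1` gives 467 nM. The measured steps are a 1.5-fold lower number from compound 1 to compound 3 (0.18 log units; within the scatter), a 3.7-fold lower number from compound 2 to compound 3 (0.57 log units; beyond the scatter) and a 2.5-fold higher number from compound 1 to compound 2 (0.39 log units; beyond the scatter). Compound 4 `CC1(C)Cc2c(sc(NC(=O)Cc3ccn[nH]3)c2C(N)=O)C(C)(C)O1` differs from compound 3 by a single change: (1H-pyrazol-5-yl)methyl in place of 1H-pyrazol-4-yl on a carbonyl carbon. Among the measured compounds shown here, none of the measured steps includes a ring carried on a methyl group; each only exchanges one ring set directly on the carbonyl carbon for another, and those exchanges moved the number at most modestly. For the measured compounds named here, the change to compound 4 has no direct precedent among the measured compounds, so the expectation rests on the modest size of those ring exchanges. A modest step in this assay is therefore expected, estimated as a 2.4-fold higher number from compound 3 to compound 4 (0.38 log units; beyond the scatter). Compound 4 is expected to give about 300 nM in this assay, with a range from 100 nM to 1200 nM.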

Compound 4, half-maximal effective concentration: 136 nM
Beside the measured number, compound 4's estimate is 2.2-fold (0.34 log units) above it, within the range that was stated.
By their numbers in this assay, from the lowest: compounds 3, 4 and 1 (each within the scatter of the next); then compound 2.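

In this assay, the ring need not sit directly on the carbonyl carbon: with (1H-pyrazol-5-yl)methyl in place of 1H-pyrazol-4-yl, the result is a 1.1-fold higher number from compound 3 to compound 4 (0.04 log units; within the scatter), although this single exchange both adds the methyl group and alters how the ring is attached. The comparison with the other two compounds gives a 1.4-fold lower number from compound 1 to compound 4 (0.15 log units; within the scatter) and a 3.4-fold lower number from compound 2 to compound 4 (0.54 log units; beyond the scatter), so the methyl-carried ring stands with the 2-hydroxypyridin-3-yl group and remains apart from the 4H-1,2,4-triazol-3-yl group. Nothing available bears on why the number holds through this change.

The compounds shown leave open how (1H-pyrazol-4-yl)methyl would compare, which would separate the effect of the methyl group from that of the ring's attachment. They also leave open whether a longer chain such as 2-(1H-pyrazol-5-yl)ethyl, or an amine or a carboxylic acid on the same methyl group, would hold the number.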